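Methoxy for methyl on a shared core that shows no activity

The compounds below may be only part of what the source reports. "The series", "measured", "known", "first", "only" and "open" are said of these compounds alone.

Compound 2 `Cc1ccc(-c2ccnc(C(=O)Nc3ccc(Oc4ccnc5[nH]ccc45)cc3)c2)cc1` carries a 4-methylphenyl on its pyridine-bearing amide core. In a functional assay on MCF7 cells (Homo sapiens) for cytotoxicity, read by MTT assay, with a stated time of 72 h (on this read-out lower numbers stand for stronger inhibition and higher numbers for weaker inhibition), compound 2 gives only a limit of the assay, > 10000 nM, and not a number. Compound 1 `COc1ccc(-c2ccc(C(=O)Nc3ccc(Oc4ccnc5[nH]ccc45)cc3)nc2)cc1`, which carries the methoxyphenyl on a differently arranged pyridine, also sits at a limit in this assay, > 10000 nM. Both values shown reach the same limit, as the limit of > 10000 nM in this assay, at which 2 of the 2 values shown sit, states. Compound 3 `COc1ccc(-c2ccnc(C(=O)Nc3ccc(Oc4ccnc5[nH]ccc45)cc3)c2)cc1` is the untested partner of compound 2: methoxy in place of methyl on an aromatic carbon. For the measured compounds named here, no measured step of this kind is available, so the expectation rests on the two limits alone. Compound 3 is expected to stay at or around the limit, with a step from compound 2 estimated as a step that the limit leaves unreadable from compound 2 to compound 3, meaning no change beyond the scatter. The estimate for compound 3 in this assay is 15000 nM, expected to fall between 7000 nM and 50000 nM.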

Compound 3, half-maximal inhibitory concentration: 8210 nM
The estimate for compound 3 lay 1.8-fold (0.26 log units) above the measured number, within the range that was stated.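

Of the three compounds shown, compound 3 is the only one with a real number rather than a limit: in this assay, compound 3 gives 8210 nM. This shows that the shared core with a 4-methoxyphenyl group can be read within the range of the assay, although the change from 4-methylphenyl to 4-methoxyphenyl amounts to an at least 1.2-fold lower number from compound 2 to compound 3 (0.08 log units; that floor lies within the scatter). From the compounds shown here alone, that floor does not establish a real gain, and the true size of the step stays unknown because compound 2 gives only a limit, not a number: the limit of > 10000 nM in this assay, at which 2 of the 3 values shown sit.

Going by these compounds, what remains open is how far compound 2 actually lies from compound 3. Also open, on these data alone, is whether an amine, a carboxylic acid or a longer chain such as ethoxy in the same place would give a clearer change in this cell assay.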